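From Butyl to Isopropyl on the Nitrogen

A few compounds are considered here, and "the series" means these few. Any claim that something is new, unique, unknown or untested is made for them only; others in the source may bear on it.

In a functional assay on HCT-116 cells (Homo sapiens) for antiproliferative activity, read by MTT assay, with a stated time of 48 h (on this read-out lower numbers stand for stronger inhibition of growth and higher numbers for weaker inhibition of growth), compound 3 (`CCCCN(Cc1ccc(C(=O)NO)cc1)c1ncc(-c2ccc(C)cc2)s1`) gives 8780 nM. Compound 1 (`CCCCCCCCN(Cc1ccc(C(=O)NO)cc1)c1ncc(-c2ccc(C)cc2)s1`) gives 6500 nM, and the step of a 1.4-fold higher number from compound 1 to compound 3 (0.13 log units; within the scatter) keeps these two values together. Compound 2 (`Cc1ccc(OCCCCN(Cc2ccc(C(=O)NO)cc2)c2ncc(-c3ccc(C)cc3)s2)cc1`) gives 580 nM. Compound 3 therefore sits at the high end of the three numbers, level with compound 1 and far from compound 2, a gap shown by the step of a 15-fold higher number from compound 2 to compound 3 (1.18 log units; beyond the scatter).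

Compound 4 (`Cc1ccc(-c2cnc(N(Cc3ccc(C(=O)NO)cc3)C(C)C)s2)cc1`) has not yet been measured. It has isopropyl in place of butyl on a nitrogen on an aromatic ring. Going by the values given here, no measured pair makes this exact exchange, so the expectation rests on indirect evidence. Among the compounds with values here, the closest guide is compound 1, where the change of a plain saturated chain produced only the step of a 1.4-fold higher number from compound 1 to compound 3 (0.13 log units; within the scatter). The large step of an 11-fold lower number from compound 1 to compound 2 (1.05 log units; beyond the scatter) came with 4-methylphenoxy on the chain, a group that compound 4 lacks. A shift beyond the scatter is therefore not expected, and the expected change is a 1.1-fold higher number from compound 3 to compound 4 (0.06 log units; within the scatter). For compound 4 the estimated value is 10000 nM, with an expected range from 4000 nM to 25000 nM.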

Compound 4, concentration for 50% growth inhibition: 7800 nM
The estimate for compound 4 lay 1.3-fold (0.11 log units) above the measured number; the measured number falls inside the stated range.
By their numbers in this assay, from the lowest: compound 2; then compounds 1, 4 and 3 (each within the scatter of the next).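

In this assay, isopropyl on the nitrogen on an aromatic ring stays level with butyl (a 1.1-fold lower number from compound 3 to compound 4 (0.05 log units; within the scatter)) and with octyl (a 1.2-fold higher number from compound 1 to compound 4 (0.08 log units; within the scatter)), so among the three plain saturated groups shown, neither the number of carbons nor the change from a straight chain to isopropyl separates the compounds on this read-out. Compound 2 remains the only one apart from the rest, and isopropyl now adds a third comparison to that gap (a 13-fold higher number from compound 2 to compound 4 (1.13 log units; beyond the scatter)), which ties the lower number to 4-(4-methylphenoxy)butyl rather than to any plain saturated group on this nitrogen. No measurement offered here explains why these groups stand together or why compound 2 differs.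

The compounds shown leave open which part of 4-(4-methylphenoxy)butyl goes with the lower number, the butyl chain carrying an oxygen, the ring at its end, or the methyl on that ring. They also cannot say how this nitrogen would respond to a group such as benzyl, or to a butyl chain ending in an amine or a carboxylic acid.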